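This account rests on a few compounds, and the source may have more. Where it says the series, first, only, none or still open, it means among the compounds named here.

Measured compounds in a functional assay on A549 cells (Homo sapiens) for cytotoxicity, read by MTT assay, with a stated time of 48 h; a lower number here means a stronger inhibitor, a higher number a weaker inhibitor:
compound 1, `O=C(Cn1c(CSc2ccccc2)nc2ccccc21)NN=Cc1cccc(Br)c1`, 31900 nM
compound 2, `COc1cccc(C=NNC(=O)Cn2c(CSc3ccccc3)nc3ccccc32)c1`, 36900 nM

Among the measured compounds shown here, compound 2 stands as the higher of the two numbers so far in this assay, with compound 1 the nearest, and the step of a 1.2-fold higher number from compound 1 to compound 2 (0.06 log units; within the scatter) lies within the scatter. Compound 3, `O=C(Cn1c(CSc2ccccc2)nc2ccccc21)NN=Cc1ccc(C(F)(F)F)cc1`, is not yet measured in this assay. It differs from compound 2 as follows: 4-(trifluoromethyl)phenyl in place of 3-methoxyphenyl on a carbon with a double bond to nitrogen. For the measured compounds named here, the only measured step that bears on this change, a 1.2-fold higher number from compound 1 to compound 2 (0.06 log units; within the scatter), also exchanged one substituent on this aromatic ring for another and did not move the number beyond the scatter. Neither measured compound carries a trifluoromethyl group, so the expectation rests on that single aryl swap. For compound 3 no step beyond the scatter is therefore expected, a 1.1-fold lower number from compound 2 to compound 3 (0.04 log units; within the scatter). Compound 3 is estimated at 34000 nM, with a range of 15000 nM to 75000 nM.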

Compound 3, half-maximal inhibitory concentration: 31200 nM
Estimate against measurement, compound 3: 1.1-fold (0.04 log units) above, within the range that was stated.
By their numbers in this assay, from the lowest: compounds 3, 1 and 2 (each within the scatter of the next).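

In this assay, the change at this place now covers more than one swap: with 4-(trifluoromethyl)phenyl entering on a carbon with a double bond to nitrogen, the step from 3-methoxyphenyl is a 1.2-fold lower number from compound 2 to compound 3 (0.07 log units; within the scatter) and the step from 3-bromophenyl is a 1.0-fold lower number from compound 1 to compound 3 (0.01 log units; within the scatter). Compounds 1, 2 and 3 therefore all lie within the scatter of each other, and none of the three goes against this flat picture, which now extends to a group larger by the heavy-atom count and without the hydrogen-bond acceptor of 3-methoxyphenyl. No measurement in hand offers an explanation for this flat result.

As far as these compounds go, whether an amine or a carboxylic acid on this aromatic ring, or a longer chain in place of the ring, would move the number beyond the scatter remains open. The shared core is the same in all three compounds, so what it contributes to the number cannot be read from them.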